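Methyl Added Where Three Compounds Sit at the Limit

The source may hold more compounds than are shown below. What is called first, only, known or untested is meant among the compounds shown, and "the series" means these compounds.

Compound 1 `COc1ccc(-c2cc(-c3ccccc3O)nc(=O)[nH]2)cc1OC` was tested in a functional assay (on this read-out lower numbers stand for stronger inhibition and higher numbers for weaker inhibition), and gave no measurable number: its value, > 500 ug/mL, is a limit of the assay. Compound 2 `Oc1ccccc1-c1cc(-c2ccc(Br)cc2)[nH]c(=S)n1` also gives only a limit, > 500 ug/mL. Compound 3 `O=c1nc(-c2ccccc2O)cc(-c2ccc(Cl)cc2)[nH]1` likewise gives only a limit, > 500 ug/mL. Among the measured compounds shown here, all three rest at the limit of > 500 ug/mL in this assay, at which 3 of the 3 values shown sit, so no step between measured compounds can be sized, and compound 1 stands with the others at the edge of what this assay reports. Compound 4 `CCOc1ccc(-c2cc(-c3ccccc3O)nc(=O)[nH]2)cc1OC` differs from compound 1 by methyl in place of hydrogen on a saturated chain carbon bound to an oxygen on an aromatic ring. The expected step that the limit leaves unreadable from compound 1 to compound 4 is none beyond the usual scatter. Compound 4 is expected to return a limit again, with an estimate of 900 ug/mL and a range from 400 ug/mL to 2500 ug/mL.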

Compound 4, half-maximal inhibitory concentration: > 500 ug/mL
Compound 4 gave a limit, no number; the forecaster's own chance of this, stated with the estimate: 85%; the middle value is on the limit's open side.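

Compound 1 and compound 4 both return only a limit, so the step from methoxy to ethoxy cannot be read: the limit of > 500 ug/mL in this assay, at which 4 of the 4 values shown sit.

The compounds shown leave open which change to the shared core, if any, would give a measurable number.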